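The source may hold more compounds than are shown below. What is called first, only, known or untested is meant among the compounds shown, and "the series" means these compounds.

Measured compounds:
compound 1 `COc1cc2c(Oc3ccc(NC(=O)c4nn(-c5ccc([N+](=O)[O-])cc5)c(=O)c5ccccc45)cc3F)ccnc2cc1OCCCN1CCCC1` 1760 nM
compound 2 `COc1cc2c(Oc3ccc(NC(=O)c4nn(-c5ccccc5F)c(=O)c5ccccc45)cc3F)ccnc2cc1OCCCN1CCN(C)CC1` 480 nM
compound 3 `COc1cc2c(Oc3ccc(NC(=O)c4nn(-c5ccc(Br)cc5)c(=O)c5ccccc45)cc3F)ccnc2cc1OCCCN1CCN(C)CC1` 850 nM

In a functional assay on HT-29 cells (Homo sapiens) for cytotoxicity, read by MTT assay, with a stated time of 72 h (on this read-out lower numbers stand for stronger inhibition and higher numbers for weaker inhibition), compound 3 gives the second highest of the three numbers: compound 2 sits within the scatter of it, while compound 1 lies beyond the scatter on the higher side. Compound 4 `COc1cc2c(Oc3ccc(NC(=O)c4nn(-c5ccc([N+](=O)[O-])cc5)c(=O)c5ccccc45)cc3F)ccnc2cc1OCCCN1CCN(C)CC1` differs from compound 3 by nitro in place of bromo on an aromatic carbon, the same change read one bond further out being 4-bromophenyl to 4-nitrophenyl. Among the compounds with values here, no measured step follows this exact change; the only single-place step, a 1.8-fold higher number from compound 2 to compound 3 (0.25 log units; within the scatter), concerns another substituent and stays within the scatter. Compound 1, which also carries the nitro group but a different amine tail, shows the highest number of the three. On that footing compound 4 is expected to show a modest rise, a 1.5-fold higher number from compound 3 to compound 4 (0.18 log units; within the scatter), with an estimate of 1300 nM and a range from 500 nM to 3400 nM.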

Compound 4, half-maximal inhibitory concentration: 2560 nM
For compound 4 the middle estimate is 2.0-fold (0.29 log units) below the measured one; low and high end bracket the measured number.
By their numbers in this assay, from the lowest: compounds 2 and 3 (each within the scatter of the next); then compounds 1 and 4 (each within the scatter of the next).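

In this assay this aromatic carbon proves sensitive: nitro in place of bromo gives a 3.0-fold higher number from compound 3 to compound 4 (0.48 log units; beyond the scatter) and is the first change on this aryl group shown to pass beyond the scatter. The 4-nitrophenyl in place of 2-fluorophenyl gives a 5.3-fold higher number from compound 2 to compound 4 (0.73 log units; beyond the scatter) while 4-methylpiperazin-1-yl in place of pyrrolidin-1-yl gives only a 1.5-fold higher number from compound 1 to compound 4 (0.16 log units; within the scatter) and so leaves the two nitro compounds together. Nothing measured here accounts for these differences.

From the compounds shown here alone, whether an amine or a carboxylic acid on this aromatic carbon would track with bromo or with nitro stays open. So does whether the pyrrolidin-1-yl tail would leave a bromo compound equally unchanged.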